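This account rests on a few compounds, and the source may have more. Where it says the series, first, only, none or still open, it means among the compounds named here.

Working notes on the series

The two measured compounds share one core and differ only at a single ring position. Compound 1, `COC1=CC(=O)c2c(COc3ccccc3)c(C)n(C)c2C1=O`, carries hydrogen there; in a functional assay on MIA PaCa-2 cells (Homo sapiens) for cytotoxicity, read by MTT assay, with a stated time of 4 h (a lower number here means a stronger inhibitor, a higher number a weaker inhibitor), compound 1 gives 4560 nM. Compound 2, `COC1=CC(=O)c2c(COc3ccc(N)cc3)c(C)n(C)c2C1=O`, carries an amino group at that carbon, and in this assay compound 2 gives 504 nM. Among the compounds with values here, the one step in hand, a 9.0-fold lower number from compound 1 to compound 2 (0.96 log units; beyond the scatter), is the whole of what the series so far says; compound 2 stands lowest of the two numbers, with compound 1 its only neighbour.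

The next compound, compound 3 `COC1=CC(=O)c2c(COc3ccc(C#N)cc3)c(C)n(C)c2C1=O`, replaces the amino group with a nitrile: cyano in place of amino on an aromatic carbon. Within the data shown here, no measured step covers an exchange of amino for cyano; the only step on record concerns hydrogen to amino, and that went to a lower number. Among the measured compounds shown here, a cyano-substituted ring has no precedent here, so the expectation for this assay is loosely held: the change is expected to move the number back toward compound 1 rather than further down, by a 4.0-fold higher number from compound 2 to compound 3 (0.60 log units; beyond the scatter), though a result within the scatter of compound 2 is not ruled out. Compound 3 is therefore estimated at 2000 nM, within 600 nM to 6500 nM.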

Compound 3, half-maximal inhibitory concentration: 463 nM
Beside the measured number, compound 3's estimate is 4.3-fold (0.64 log units) above it, outside the stated range (below it).
By their numbers in this assay, from the lowest: compounds 3 and 2 (each within the scatter of the next); then compound 1.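

In this assay the exchange of amino for cyano on this aromatic carbon, para to a large group, gives a 1.1-fold lower number from compound 2 to compound 3 (0.04 log units; within the scatter) and so does not separate compound 2 from compound 3, although cyano is a group without a hydrogen-bond donor and amino carries one. Measured against hydrogen at the same carbon, the nitrile gives a 9.8-fold lower number from compound 1 to compound 3 (0.99 log units; beyond the scatter) and the amino group gives a 9.0-fold lower number from compound 1 to compound 2 (0.96 log units; beyond the scatter); both steps lie beyond the scatter, so among these three compounds the gap from compound 1 does not depend on a hydrogen-bond donor in the entering group. Nothing available explains why two such different groups give values within the scatter of each other.

Going by these compounds, whether the gap from hydrogen extends beyond amino and cyano remains open, and a carboxylic acid, a methoxy group, a chlorine atom or a longer alkyl chain at this carbon would test it. Also open, on these data alone, is whether either group would give a similar step at another carbon of the same ring, or on a different core, since all three compounds share one core and one assay.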